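A few compounds are considered here, and "the series" means these few. Any claim that something is new, unique, unknown or untested is made for them only; others in the source may bear on it.

The compounds share one core, shown for compound 1 as `Cc1ccsc1/C=C(/SCc1ccc(F)cc1)C(=O)c1ccc(Br)cc1`. Among the measured compounds shown here, in a functional assay on DU-145 cells (Homo sapiens) for inhibition, read by trypan blue exclusion, with a stated time of 96 h (a lower number here means a stronger inhibitor of growth, a higher number a weaker inhibitor of growth), compound 1 gives 50000 nM, the highest of the three numbers known. Compound 2, `Cc1ccsc1/C=C(/SCc1ccc(Cl)cc1)C(=O)c1ccc(Br)cc1`, gives 25000 nM in this assay, a step of a 2.0-fold lower number from compound 1 to compound 2 (0.30 log units; within the scatter). For the measured compounds named here, compound 3, `O=C(/C(=C\c1ccc(I)cc1)S(=O)(=O)c1ccc(Br)cc1)c1ccc(Br)cc1`, gives 1000 nM in this assay; it differs from compound 1 in more than one place, so no single step links the two, and their values show only that compound 3 lies far lower. The unmeasured compound 4, `Cc1cc(F)ccc1/C=C(/SCc1ccc(F)cc1)C(=O)c1ccc(Br)cc1`, differs from compound 1 by 4-fluoro-2-methylphenyl in place of 3-methylthiophen-2-yl on a double-bonded chain carbon bound to a double-bonded chain carbon. Going by the values given here, no measured step touches this part of the molecule: the only single step, from fluoro to chloro, changed a different ring and stayed within the scatter. Compound 3 also carries a six-membered aromatic ring of carbon only on its double-bonded chain carbon and is much lower, but its other differences prevent attributing that gap to the ring. Compound 4 is therefore expected to stay close to compound 1, with a small lean toward a lower number, a 2.0-fold lower number from compound 1 to compound 4 (0.30 log units; within the scatter). The estimate for compound 4 is 25000 nM, with a range from 8000 nM to 80000 nM.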

Compound 4, concentration for 50% growth inhibition: 10000 nM
Estimate against measurement, compound 4: 2.5-fold (0.40 log units) above; measured number inside the range.
By their numbers in this assay, from the lowest: compound 3; then compound 4; then compounds 2 and 1 (each within the scatter of the next).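

In this assay the exchange of 3-methylthiophen-2-yl for 4-fluoro-2-methylphenyl on a double-bonded chain carbon bound to a double-bonded chain carbon gives a 5.0-fold lower number from compound 1 to compound 4 (0.70 log units; beyond the scatter). Among the compounds shown here, this shows that the number responds to a change at this position, though modestly, whereas the only earlier single step changed a different ring and stayed within the scatter. Nothing shown explains this shift.

The step replaces one whole group with another, so the compounds shown leave open how much of it belongs to the ring itself, the fluoro or the methyl. Going by these compounds, it also remains open how the number would move with a plain phenyl, or with a ring carrying an amine or a carboxylic acid, at this position.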